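The compounds below may be only part of what the source reports. "The series", "measured", "known", "first", "only" and "open" are said of these compounds alone.

In a functional assay, with a stated time of 30 min (on this read-out higher numbers stand for weaker inhibition and lower numbers for stronger inhibition), compound 1 (`CCCCCCOc1cc(OC)ccc1C(C)=O`) gives 42600000 nM and compound 2 (`CCCCCCCCCCOc1cc(OC)ccc1C(C)=O`) gives 40100000 nM, so the two values lie within the scatter of each other. Compound 3 (`CCCCCCCCCCCCCCOc1cc(OC)ccc1C(C)=O`) lengthens the chain again: butyl in place of hydrogen on a saturated chain carbon, ten or more bonds along the chain from an oxygen on an aromatic ring. For the measured compounds named here, only one measured step bears on this, the same butyl exchange made six bonds along the chain from the oxygen on the aromatic ring. That step, a 1.1-fold lower number from compound 1 to compound 2 (0.03 log units; within the scatter), stayed within the scatter. Going by that step, no change beyond the scatter is expected in this assay. The expected change is a 1.0-fold lower number from compound 2 to compound 3 (0.00 log units; within the scatter). For compound 3 the estimated value is 40000000 nM, with an expected range of 15000000 nM to 100000000 nM.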

Compound 3, half-maximal inhibitory concentration: 43600000 nM
Compound 3: middle estimate off by 1.1-fold (0.04 log units), on the low side, within the range that was stated.
By their numbers in this assay, from the lowest: compounds 2, 1 and 3 (each within the scatter of the next).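

In this assay, the butyl exchange on a saturated chain carbon of the chain on the oxygen on the aromatic ring also stays within the scatter, with a 1.1-fold higher number from compound 2 to compound 3 (0.04 log units; within the scatter). The larger exchange, octyl in place of hydrogen six bonds along the chain, gives a 1.0-fold higher number from compound 1 to compound 3 (0.01 log units; within the scatter), so the values of these three compounds do not separate even across the widest change in chain length shown. No supporting evidence bears on this result. As far as these compounds go, whether a shorter chain such as methyl, or a chain ending in an amine or a carboxylic acid, would give a different value remains open.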